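Swapping Fluoro for Bromo on an Aromatic Ring

The compounds below may be only part of what the source reports. "The series", "measured", "known", "first", "only" and "open" are said of these compounds alone.

In a functional assay on SW-620 cells (Homo sapiens) (on this read-out lower numbers stand for stronger inhibition of growth and higher numbers for weaker inhibition of growth), compound 3 (`COc1cc2ncnc(Nc3ccc(CS(=O)(=O)/C=C/c4ccc(F)cc4)cc3)c2cc1OC`) gives > 100000 nM, which is a limit of the assay and not a number. Compound 3 therefore has no exact position on the scale. Compound 4 (`COc1cc2ncnc(Nc3ccc(CS(=O)(=O)/C=C/c4ccc(Br)cc4)cc3)c2cc1OC`) differs from compound 3 in one place: bromo in place of fluoro on an aromatic carbon.

Within the data shown here, one measured step bears on this site. Compound 2 (`COc1cc2ncnc(Nc3ccc(CS(=O)(=O)/C=C/c4ccc(Cl)cc4Cl)cc3)c2cc1OC`), which carries a 2,4-dichlorophenyl group, gives 2000 nM. Exchanging that group for 4-fluorophenyl is a large change, an at least 50-fold higher number from compound 2 to compound 3 (1.69 log units; beyond the scatter), so this part of the molecule clearly matters in this assay. Compound 1 (`O=S(=O)(/C=C/c1ccc(F)cc1F)Cc1ccc(Nc2ncnc3ccc(Br)cc23)cc1`) gives 100000 nM, but it differs from the others in more than one place and offers no clean comparison.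

Compound 4 keeps a single halogen on this ring, but it is no longer fluoro, so a partial move towards compound 2 seems likely. The estimated change is an at least 5.0-fold lower number from compound 3 to compound 4 (0.69 log units; beyond the scatter), and this expectation is uncertain because the starting point is only a limit. For compound 4 the expected value is 20000 nM, with an estimated range from 3000 nM to 100000 nM.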

Compound 4, concentration for 50% growth inhibition: 5000 nM
Compound 4: the middle estimate sits 4.0-fold (0.60 log units) above what was measured, within the range that was stated.
By their numbers in this assay, from the lowest: compound 2; then compound 4; then compound 1.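

Exchanging fluoro for bromo on this aromatic carbon gives an at least 20-fold lower number from compound 3 to compound 4 (1.30 log units; beyond the scatter) in this assay, so the identity of this single halogen matters, not merely the presence of a halogen on the ring. The earlier step from compound 2 to compound 3 changed the number of halogens and their kind together, and it could not separate the two; compound 4 now shows that a single bromo recovers most of the lost activity, leaving only a modest gap of a 2.5-fold higher number from compound 2 to compound 4 (0.40 log units; beyond the scatter). Compound 3 stands at a limit and not a number, so the step from it has a floor only and its full size remains unknown: the limit of > 100000 nM in this assay, at which 1 of the 4 values shown sits.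

The compounds shown do not tell whether a 4-chlorophenyl group would fall nearer to compound 4 or to compound 3, or how an amine or a carboxylic acid on this aromatic carbon would behave. They also give no measured property of these halogens that could explain why bromo and fluoro differ so strongly here.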